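This account rests on a few compounds, and the source may have more. Where it says the series, first, only, none or still open, it means among the compounds named here.

Compound 1 `Cc1cc(S(N)(=O)=O)ccc1NC(=O)COc1ccc(Cl)cc1NC(=O)c1cccc([N+](=O)[O-])c1` gives 58800 nM in a functional assay on C8166 cells (Homo sapiens) for cytotoxicity, read by MTT assay; on this read-out lower numbers stand for higher toxicity in this test and higher numbers for lower toxicity in this test.
Compound 2 `Cc1cc(S(N)(=O)=O)ccc1NC(=O)COc1ccc(Cl)cc1NC(=O)c1cc(Cl)cc(Br)c1` gives 114000 nM in this assay.

Within the data shown here, compound 1 has the lower of the two numbers, but its only neighbour is compound 2, and the step of a 1.9-fold higher number from compound 1 to compound 2 (0.29 log units; within the scatter) does not rise out of the scatter, so the two compounds cannot be told apart on this read-out. Compound 3 `Cc1cc(S(N)(=O)=O)ccc1NC(=O)COc1ccc(Cl)cc1NC(=O)/C=C/c1ccccc1` has not yet been tested in this assay. It differs from compound 1 in one place: 2-phenylethenyl in place of 3-nitrophenyl on a carbonyl carbon. Among the measured compounds shown here, the only measured step that touches the same carbonyl carbon is a 1.9-fold higher number from compound 1 to compound 2 (0.29 log units; within the scatter), where one aromatic group was exchanged for another and the number stayed within the scatter. The group entering in compound 3 is of a different kind, so that step is only a loose guide, but it is the only one available, and it gives no reason to expect a large shift. For compound 3 the expected outcome is a step of a 1.2-fold higher number from compound 1 to compound 3 (0.08 log units; within the scatter), which stays within the scatter. Compound 3 is therefore estimated at 70000 nM in this assay, with a range from 25000 nM to 200000 nM.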

Compound 3, half-maximal cytotoxic concentration: 163000 nM
Estimate against measurement, compound 3: 2.3-fold (0.37 log units) below; the measured number falls inside the stated range.
By their numbers in this assay, from the lowest: compounds 1, 2 and 3 (each within the scatter of the next, the first and the last beyond it).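

In this assay, this carbonyl carbon now shows its first step beyond the scatter: a 2.8-fold higher number from compound 1 to compound 3 (0.44 log units; beyond the scatter), a modest move towards lower toxicity in this test when 3-nitrophenyl gives way to 2-phenylethenyl, a group made of carbon only. The other exchange, a 1.4-fold higher number from compound 2 to compound 3 (0.16 log units; within the scatter), stays within the scatter, so 2-phenylethenyl and 3-bromo-5-chlorophenyl cannot be told apart here, just as 3-bromo-5-chlorophenyl and 3-nitrophenyl could not, and only the two ends of this short series separate. No independent measurement accompanies these numbers to explain the separation, so it stands as an observation only.

Still open, on these data alone, is whether the step belongs to the loss of the nitro group or to the change from a ring on the carbonyl carbon to 2-phenylethenyl, as this exchange alters both at once. A plain phenyl group or a 2-phenylethyl group on the same carbonyl carbon would help separate those two readings, and an amine or a carboxylic acid on the ring would show whether this position tolerates a much wider range of groups.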